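This account rests on a few compounds, and the source may have more. Where it says the series, first, only, none or still open, it means among the compounds named here.

Measured in a functional assay on the whole organism (strain Sprague-Dawley) for inhibition, with Rattus norvegicus as the target, with a stated time of 10 min; on this read-out lower numbers stand for an effect already at smaller amounts and higher numbers for an effect only at larger amounts of compound:
- compound 1 `COc1ccc(OC)c(-c2ncc(C(=O)O)c(=O)[nH]2)c1`: 1 mg/kg
- compound 2 `CCOc1ccc(OC)cc1-c1ncc(C(=O)O)c(=O)[nH]1`: 0.2 mg/kg
- compound 3 `CCOC(=O)c1cnc(-c2cc(OC)ccc2OC)[nH]c1=O`: 5 mg/kg

Compound 3 has the highest number of the three in this assay, at 5 mg/kg, so it needs the largest dose in this small set.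

Compound 4 `CCOC(=O)c1cnc(-c2cc(OC)ccc2OCC)[nH]c1=O` differs from compound 3 by methyl in place of hydrogen on a saturated chain carbon bound to an oxygen on an aromatic ring, that is, methoxy to ethoxy.

The same change has been measured once, on the compound without the ethyl on the oxygen next to the carbonyl group: a 5.0-fold lower number from compound 1 to compound 2 (0.70 log units; beyond the scatter). The other measured step, a 5.0-fold higher number from compound 1 to compound 3 (0.70 log units; beyond the scatter), is the change that separates these two settings and does not measure the methoxy to ethoxy change itself. Within the data shown here, whether the single step carries over to the ester remains untested, so a similar step in the same direction is expected, with some shrinkage and a wide range. The expected step is a 4.2-fold lower number from compound 3 to compound 4 (0.62 log units; beyond the scatter). Compound 4 is estimated at 1.2 mg/kg, with an expected range of 0.4 mg/kg to 4 mg/kg.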

Compound 4, dose for 50% inhibition: 0.3 mg/kg
Estimate against measurement, compound 4: 4.0-fold (0.60 log units) above, and the stated range ends above it.
By their numbers in this assay, from the lowest: compounds 2 and 4 (each within the scatter of the next); then compound 1; then compound 3.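

Methoxy to ethoxy at this position is not confined to the free carboxylic acid: on the ester it gives a 17-fold lower number from compound 3 to compound 4 (1.22 log units; beyond the scatter). The size of the gain depends on the setting, and the step on the ester is the larger one: the same change on two cores in this assay, a 5.0-fold lower number (0.70 log units; beyond the scatter) from compound 1 to compound 2 and a 17-fold lower number (1.22 log units; beyond the scatter) from compound 3 to compound 4, 3.3-fold (0.52 log units) apart, beyond the scatter of two such steps

With ethoxy in place, adding the ethyl on the oxygen next to the carbonyl group gives only a 1.5-fold higher number from compound 2 to compound 4 (0.18 log units; within the scatter), so the effect of that ethyl depends on the group at the other site: the same change on two cores in this assay, a 5.0-fold higher number (0.70 log units; beyond the scatter) from compound 1 to compound 3 and a 1.5-fold higher number (0.18 log units; within the scatter) from compound 2 to compound 4, 3.3-fold (0.52 log units) apart, beyond the scatter of two such steps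

Still open, on these data alone, is whether a propyl or a longer chain on the aromatic oxygen extends the gain seen with ethoxy or reverses it. As far as these compounds go, it is also open whether an amide in place of the ester would show the same dependence on that chain.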